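The source may report more compounds than this note shows. Statements on the series, on what has been measured and on what is new or still open speak of the compounds shown alone.

Measured so far:
- compound 1, `COc1ccc2c(c1)CCC(NC[C@H]1CC[C@H](CNS(=O)(=O)c3ccc4ccccc4c3)CC1)C2Cc1cccnc1`: 337 nM
- compound 2, `COc1ccc2c(c1)CCC(NC[C@H]1CC[C@H](CNS(=O)(=O)c3ccccc3)CC1)C2Cc1cccnc1`: 10 nM

For the measured compounds named here, in an assay on HEK293 cells for binding affinity to Neuropeptide Y receptor type 5 (Homo sapiens) (on this read-out lower numbers stand for stronger inhibition and higher numbers for weaker inhibition), compound 2 gives the lowest of the two numbers; its only neighbour is compound 1, and the step of a 34-fold lower number from compound 1 to compound 2 (1.53 log units; beyond the scatter) is large and well beyond the scatter. Compound 3, `O=S(=O)(NC[C@H]1CC[C@H](CNC2CCc3cc(F)ccc3C2Cc2cccnc2)CC1)c1ccccc1`, differs from compound 2 in one place: fluoro in place of methoxy on an aromatic carbon.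

Going by the values given here, the single measured step concerns the group on the sulfonyl sulfur and leaves the aromatic carbon of the fused system untouched, so no measured step bears on the present change. Nothing here points in either direction for the exchange of methoxy for fluoro. The working expectation is therefore a step of a 1.5-fold higher number from compound 2 to compound 3 (0.18 log units; within the scatter), within the usual scatter. Compound 3 is estimated at 15 nM in this assay, with a range from 5 nM to 45 nM.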

Compound 3, half-maximal inhibitory concentration: 27 nM
The estimate for compound 3 lay 1.8-fold (0.26 log units) below the measured number; the measured number falls inside the stated range.
By their numbers in this assay, from the lowest: compound 2; then compound 3; then compound 1.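

In this assay, fluoro in place of methoxy on this aromatic carbon gives a 2.7-fold higher number from compound 2 to compound 3 (0.43 log units; beyond the scatter), the first sign that this position of the shared core registers a change beyond the scatter. The step is modest, whereas a 34-fold lower number from compound 1 to compound 2 (1.53 log units; beyond the scatter), at the sulfonyl sulfur, is large, so both places affect the number, with the larger step at the sulfonyl sulfur. Nothing available explains the direction or size of the methoxy to fluoro step.

Going by these compounds, it remains open whether the higher number follows from losing methoxy or from introducing fluoro, and a hydroxy, chloro or methyl group on the same aromatic carbon would help separate the two. Also open, on these data alone, is whether this step holds with naphthalen-2-yl on the sulfonyl sulfur, as in compound 1.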